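A few compounds are considered here, and "the series" means these few. Any claim that something is new, unique, unknown or untested is made for them only; others in the source may bear on it.

Compound 2 `CC(C)(C)N(NC(=O)c1ccc(C#N)cc1)C(=O)c1ccccc1Cl` is, in an assay on cells for agonist activity at ecdysone receptor (Bombyx mori), read by a luciferase reporter, with a stated time of 24 h (a higher number here means that more compound is needed for the effect, a lower number that less compound is needed), the higher of the two measured numbers: compound 2 gives 603 nM, whereas compound 1 `CC(C)(C)N(NC(=O)c1ccccc1F)C(=O)c1ccccc1Cl` gives 51.3 nM. Within the data shown here, the one step between them, a 12-fold higher number from compound 1 to compound 2 (1.07 log units; beyond the scatter), shows that exchanging the aryl group on this carbonyl carbon can move the number a long way. Compound 3 `Cc1ccc(C)c(C(=O)NN(C(=O)c2ccccc2Cl)C(C)(C)C)c1` is the next exchange at the same place: 2,5-dimethylphenyl in place of 4-cyanophenyl on a carbonyl carbon. Among the measured compounds shown here, no measured step involves the 2,5-dimethylphenyl group itself, so the only guide is that the 4-cyanophenyl group of compound 2 stands out as the unfavourable one; removing it is expected to bring the number back down, though it is uncertain whether fully to the level of compound 1. For compound 3 the step of an 8.6-fold lower number from compound 2 to compound 3 (0.94 log units; beyond the scatter) is therefore expected. Compound 3 is thus estimated at 70 nM in this assay, within a range from 15 nM to 300 nM.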

Compound 3, half-maximal effective concentration: 1620 nM
Compound 3: middle estimate off by 23-fold (1.36 log units), on the low side; the measured number lies above the stated range.
By their numbers in this assay, from the lowest: compound 1; then compound 2; then compound 3.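

In this assay, removing the 4-cyanophenyl group did not bring the number back down: putting 2,5-dimethylphenyl on this carbonyl carbon gives a 2.7-fold higher number from compound 2 to compound 3 (0.43 log units; beyond the scatter), so the 4-cyanophenyl group is not the one unfavourable exception here. Set against the 2-fluorophenyl group, the same 2,5-dimethylphenyl group gives a 32-fold higher number from compound 1 to compound 3 (1.50 log units; beyond the scatter), which makes compound 1 the one with the lowest number of the three and shows that this position tolerates few of the exchanges seen so far. No data are available to explain why these aryl groups differ.

The compounds shown leave open whether the high number of compound 3 comes from one methyl group alone or from the pair. They also leave open where a plain unsubstituted phenyl, or a phenyl carrying a methoxy group, would fall.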